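Bromo for Methyl on the Benzyl Ring of Compound 2

The source may hold more compounds than are shown below. What is called first, only, known or untested is meant among the compounds shown, and "the series" means these compounds.

Measured compounds:
compound 1, `Brc1ccccc1COc1nc2ccccc2s1`: 75.6%
compound 2, `Cc1ccc(COc2nc3ccccc3s2)cc1`: 1.95%

In a functional assay on the whole organism with Mus musculus as the target, with a stated time of 1 h, at a dose of 100 mg/kg by the intraperitoneal route (a higher number here means more inhibition at the dose given (going by the name of the read-out), a lower number less inhibition), compound 1 gives 75.6%. Compound 2, in this assay, gives 1.95%, the lower of the two numbers, and the gap to compound 1 lies beyond the scatter. For the measured compounds named here, compound 1 and compound 2 differ in more than one place, so the two values show only that one compound inhibits strongly and the other hardly at all.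

The unmeasured compound 3, `Brc1ccc(COc2nc3ccccc3s2)cc1`, arises from compound 2 by a single change: bromo in place of methyl on an aromatic carbon, on an aromatic carbon of a six-membered aromatic ring of carbon only.

Going by the values given here, no step between two measured compounds matches this change, so the size of the step cannot be read from the data. Among the compounds with values here, a bromo group is present in compound 1, which gives 75.6%, while compound 2 with methyl gives 1.95%; with this as the only guide, the step from compound 2 to compound 3 is expected to be upward and beyond the scatter, about a number 33.1 percentage points higher from compound 2 to compound 3 (beyond the scatter). Compound 3 is therefore estimated to give 35% in this assay, within a range from 5% to 70%.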

Compound 3, a percentage reported as inhibition, in the whole organism at one dose (the size of the read-out at that dose, not a potency): 78%
Estimate against measurement, compound 3: 43 percentage points below, outside the stated range (above it).
By their numbers in this assay, from the lowest: compound 2; then compounds 1 and 3 (each within the scatter of the next).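

In this assay, bromo in place of methyl on an aromatic carbon of the six-membered aromatic ring, para to a large group, gives a number 76.1 percentage points higher from compound 2 to compound 3 (beyond the scatter). For the compounds shown here, this is the first reading of a single change, and it shows that the read-out at this position is highly sensitive to which of these two groups is present, whereas the earlier comparison of compounds differing in more than one place could not tie the gap to any one site. The exchange replaces one heavy atom with one heavy atom and leaves the counts of rings, hydrogen-bond donors, hydrogen-bond acceptors and net charge unchanged, so those counts do not separate the two compounds, and nothing in the available data accounts for the size of the step.

The compounds shown leave open whether bromo is specifically needed at this position, or whether chloro, an amine or a carboxylic acid there would give a similar number. On these data alone, they also leave open what a plain hydrogen at this position gives, so it remains unknown whether the step reflects a gain from bromo, a loss from methyl, or both.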